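Swapping a Chlorobenzylamino Arm for Two Hydroxypropyl Chains

The source may report more compounds than this note shows. Statements on the series, on what has been measured and on what is new or still open speak of the compounds shown alone.

Compounds measured so far:
Compound 1, `CC(C)CNc1ccc(NC(=O)c2cc(Cl)ccc2O)c(Cl)c1`, gives 60000 nM in an ADME assay on A549 cells (Homo sapiens) for cytotoxicity, read by resazurin assay, with a stated time of 48 h; a higher number here means that more compound is tolerated, a lower number that less compound is tolerated.
Compound 2, `CN(C)c1ccc(NC(=O)c2cc(Cl)ccc2O)c(Cl)c1`, gives 85100 nM.
Compound 3, `O=C(Nc1ccc(NCc2ccc(Cl)cc2)cc1Cl)c1cc(Cl)ccc1O`, gives 59700 nM.

All three share the same core and differ only in the amino group on the outer ring. On the numbers, compound 3 carries the smallest value of the three, but this means little: the steps of a 1.0-fold lower number from compound 1 to compound 3 (0.00 log units; within the scatter) and a 1.4-fold lower number from compound 2 to compound 3 (0.15 log units; within the scatter) both stay within the scatter, so the three compounds cannot be told apart.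

Compound 4, `O=C(Nc1ccc(N(CCCO)CCCO)cc1Cl)c1cc(Cl)ccc1O`, has not yet been measured. The change from compound 3 is bis(3-hydroxypropyl)amino in place of (4-chlorobenzyl)amino on an aromatic carbon.

The steps that speak to this change are those at the same aromatic carbon. The step of a 1.4-fold higher number from compound 1 to compound 2 (0.15 log units; within the scatter) exchanges one amino substituent for another and does nothing beyond the scatter, as do a 1.0-fold lower number from compound 1 to compound 3 (0.00 log units; within the scatter) and a 1.4-fold lower number from compound 2 to compound 3 (0.15 log units; within the scatter). Going by the values given here, no measured step introduces hydroxyl groups, so the new arm is untested ground; still, every exchange at this position so far has left this assay unchanged.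

The estimate for compound 4 is therefore a step of a 1.2-fold higher number from compound 3 to compound 4 (0.08 log units; within the scatter), not expected to pass beyond the scatter. Compound 4 is estimated at 72000 nM, with a range from 35000 nM to 150000 nM.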

Compound 4, half-maximal cytotoxic concentration: 114000 nM
Compound 4: middle estimate off by 1.6-fold (0.20 log units), on the low side, within the range that was stated.
By their numbers in this assay, from the lowest: compounds 3, 1, 2 and 4 (each within the scatter of the next).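

In this assay, the step of a 1.9-fold higher number from compound 3 to compound 4 (0.28 log units; within the scatter) removes the aromatic ring of the (4-chlorobenzyl)amino arm and brings in a ringless bis(3-hydroxypropyl)amino arm with more hydrogen-bond donors and acceptors, yet it stays within the scatter. The steps of a 1.3-fold higher number from compound 2 to compound 4 (0.13 log units; within the scatter) and a 1.9-fold higher number from compound 1 to compound 4 (0.28 log units; within the scatter) also stay within the scatter, so the aromatic carbon now tolerates hydroxyl-bearing chains as well as the dimethylamino, isobutylamino and (4-chlorobenzyl)amino groups, with no reading that separates any of the four compounds. Nothing available gives a reason for this flat picture.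

As far as these compounds go, it remains open whether a group of another kind at this carbon, such as a carboxylic acid at the end of a chain or a piperazine ring, would move the number in this assay beyond the scatter. All four compounds also keep the same shared core, so these results say nothing about whether the amino arm would matter as little if the chloro group on that ring gave way to a methoxy group.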